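The source may report more compounds than this note shows. Statements on the series, on what has been measured and on what is new or still open speak of the compounds shown alone.

Measured in a functional assay on MCF7 cells (Homo sapiens) for inhibition, read by MTT assay, with a stated time of 72 h; a higher number here means a weaker inhibitor of growth, a lower number a stronger inhibitor of growth:
compound 1 `O=S(=O)(NCCCNCC1COc2ccccc2O1)c1cc(C(F)(F)F)cc(C(F)(F)F)c1`: 2500 nM
compound 2 `CN(CCCNS(=O)(=O)c1cc(C(F)(F)F)cc(C(F)(F)F)c1)Cc1ccccc1`: 16000 nM
compound 3 `O=S(=O)(NCCCNCc1ccccc1)c1cc(C(F)(F)F)cc(C(F)(F)F)c1`: 3000 nM

Compound 3 stands second highest of the three numbers; the step of a 1.2-fold higher number from compound 1 to compound 3 (0.08 log units; within the scatter) lies within the scatter, whereas a 5.3-fold lower number from compound 2 to compound 3 (0.73 log units; beyond the scatter) lies beyond it. Compound 4 is `O=S(=O)(NCCCNCc1ccc(Cl)cc1)c1cc(C(F)(F)F)cc(C(F)(F)F)c1` and differs from compound 3 by chloro in place of hydrogen on an aromatic carbon. Within the data shown here, no measured step places a substituent on this aromatic ring. The nearest comparison is the exchange of the whole group on the chain carbon, a 1.2-fold higher number from compound 1 to compound 3 (0.08 log units; within the scatter), which stayed within the scatter; the step of a 5.3-fold lower number from compound 2 to compound 3 (0.73 log units; beyond the scatter) concerns the amine nitrogen and does not bear on this change. Among the measured compounds shown here, with no measured step at this position, compound 4 is expected to show a step of a 1.2-fold lower number from compound 3 to compound 4 (0.08 log units; within the scatter), within the scatter. Compound 4 is therefore estimated at 2500 nM, with a range from 900 nM to 7000 nM.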

Compound 4, concentration for 50% growth inhibition: 2400 nM
Beside the measured number, compound 4's estimate is 1.0-fold (0.02 log units) above it, and the stated range covers the measured number.
By their numbers in this assay, from the lowest: compounds 4, 1 and 3 (each within the scatter of the next); then compound 2.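

In this assay, among these compounds, the step of a 1.3-fold lower number from compound 3 to compound 4 (0.10 log units; within the scatter) is the first on this aromatic ring and shows that chloro para to a large group leaves the number within the scatter. The step of a 1.0-fold lower number from compound 1 to compound 4 (0.02 log units; within the scatter) also stays within the scatter, whereas a 6.7-fold lower number from compound 2 to compound 4 (0.82 log units; beyond the scatter) lies beyond it and keeps compound 2 apart from the compounds with hydrogen on the amine nitrogen. No available evidence bears on these steps.

As far as these compounds go, whether methoxy, nitrile or an amine in place of chloro would shift the number remains open. So does the outcome of a longer chain.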